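Swapping the aryl group on the pyrazole core

A few compounds are considered here, and "the series" means these few. Any claim that something is new, unique, unknown or untested is made for them only; others in the source may bear on it.

Measured compounds:
- compound 1, `Cc1cc(Cl)cc(-c2c(C)nn(-c3nc(-c4ccc(Cl)c(Cl)c4)c(SC(C)C)s3)c2C(=O)O)c1`: 663 nM
- compound 2, `Cc1cc(C#N)cc(-c2c(C)nn(-c3nc(-c4ccc(Cl)c(Cl)c4)c(SC(C)C)s3)c2C(=O)O)c1`: 4800 nM

Of the compounds shown here, two have been measured in a functional assay on BJAB cells (Homo sapiens) for antiproliferative activity, with a stated time of 4 days; a lower number here means that less compound is needed, a higher number that more compound is needed for the effect. Compound 1 gives 663 nM, and compound 2 gives 4800 nM. Among the measured compounds shown here, compound 2 stands as the higher of the two numbers, the only neighbour being compound 1, and the step of a 7.2-fold higher number from compound 1 to compound 2 (0.86 log units; beyond the scatter) is the single measured comparison available.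

Compound 3, `Cc1nn(-c2nc(-c3ccc(Cl)c(Cl)c3)c(SC(C)C)s2)c(C(=O)O)c1-c1cccc(Cl)c1C`, has not yet been measured. Its change from compound 2 is 3-chloro-2-methylphenyl in place of 3-cyano-5-methylphenyl on an aromatic carbon. This change brings back a chloro group in place of the cyano and at the same time moves the methyl group within the ring. For the measured compounds named here, the only measured step that bears on it is a 7.2-fold higher number from compound 1 to compound 2 (0.86 log units; beyond the scatter), where cyano in place of chloro gave the higher number; compound 3 reverses that part of the change, so a lower number is expected, roughly undoing that step. Going by the values given here, the shift of the methyl has no measured counterpart, so the expectation is widened.

Compound 3 is therefore estimated at 900 nM, within 300 nM to 3000 nM, meaning a 5.3-fold lower number from compound 2 to compound 3 (0.73 log units; beyond the scatter) is expected.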

Compound 3, half-maximal effective concentration: 5100 nM
Compound 3: middle estimate off by 5.7-fold (0.75 log units), on the low side, outside the stated range (above it).
By their numbers in this assay, from the lowest: compound 1; then compounds 2 and 3 (each within the scatter of the next).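

Compound 1 and compound 3 carry the same chloro group and differ only in the aryl pattern, with 3-chloro-2-methylphenyl in place of 3-chloro-5-methylphenyl on the core. In this assay this gives a 7.7-fold higher number from compound 1 to compound 3 (0.89 log units; beyond the scatter), so at this position the place of the methyl on the aryl ring can alone produce a step beyond the scatter, which the earlier swap of chloro for cyano could not show. The other new comparison gives a 1.1-fold higher number from compound 2 to compound 3 (0.03 log units; within the scatter), so the two different aryl groups of these compounds cannot be told apart here, and a chloro group on this ring does not by itself go with the value of compound 1; nothing measured here explains why the methyl's place matters.

The compounds shown leave open how 3-cyano-2-methylphenyl would read, a group that would test the cyano and chloro groups with the methyl in this second place. They also leave open whether a plain phenyl, or a ring bearing a methoxy group or an amine, would fit this position.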